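Sulfonamide in Place of the Dienoyl Amide in Compound 4

The compounds below may be only part of what the source reports. "The series", "measured", "known", "first", "only" and "open" are said of these compounds alone.

Compound 3 `C/C=C/C=C/C(=O)N[C@H](C(=O)NCCCCCCCCCCCC)[C@@H](C)O` gives 200000 nM in a functional assay on SW-620 cells (Homo sapiens) for cytotoxicity, read by MTT assay, with a stated time of 48 h; on this read-out lower numbers stand for stronger inhibition and higher numbers for weaker inhibition. Compound 2 `CCCCCCCCCCCCNC(=O)[C@@H](NC(=O)/C=C/c1ccccc1)[C@@H](C)O` gives 200000 nM in this assay, and no change at the digits printed from compound 2 to compound 3 (within the scatter). Compound 1 `CCCCCCCCCCCCNC(=O)[C@@H](NC(=O)c1ccco1)[C@@H](C)O` gives 87500 nM; here a 2.3-fold higher number from compound 1 to compound 3 (0.36 log units; beyond the scatter), and likewise a 2.3-fold higher number from compound 1 to compound 2 (0.36 log units; beyond the scatter). So compound 3 stands level with compound 2 at the highest of the three numbers, with compound 1 the only lower one. Compound 4 `CCCCCCCCCCCCNC(=O)[C@@H](NS(=O)(=O)c1cccs1)[C@@H](C)O` differs from compound 3 by (thiophen-2-yl)sulfonyl in place of (penta-1,3-dien-1-yl)carbonyl on an amine nitrogen. Within the data shown here, no measured step swaps a carbonyl for a sulfonyl, so the only hint is compound 1, whose five-membered aromatic ring gave the lowest number. A modest downward step is therefore expected, a 2.0-fold lower number from compound 3 to compound 4 (0.30 log units; within the scatter). The estimate for compound 4 is 100000 nM, ranging from 40000 nM to 200000 nM.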

Compound 4, half-maximal inhibitory concentration: 27900 nM
Beside the measured number, compound 4's estimate is 3.6-fold (0.55 log units) above it; measured number below the stated range.
By their numbers in this assay, from the lowest: compound 4; then compound 1; then compounds 2 and 3 (each within the scatter of the next).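

Among these compounds, the (thiophen-2-yl)sulfonyl group on the amine nitrogen gives the lowest number so far in this assay, with (a 7.2-fold lower number from compound 3 to compound 4 (0.86 log units; beyond the scatter)) and (a 7.2-fold lower number from compound 2 to compound 4 (0.86 log units; beyond the scatter)). It also passes the furan-2-yl amide (a 3.1-fold lower number from compound 1 to compound 4 (0.50 log units; beyond the scatter)), so this position accepts a sulfonyl link as well as a carbonyl. Nothing available explains this drop. On these data alone, each step changes the link and the attached group together, so the share of each stays open. Thiophen-2-yl joined through a carbonyl, or phenyl joined through a sulfonyl, would separate the two.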